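The compounds below may be only part of what the source reports. "The series", "measured", "known", "first", "only" and "open" are said of these compounds alone.

Working notes on the series. Compound 1 (`COc1ccc(/C=C/c2cc(OC)c(OC)c(OC)c2-c2ccc(OC)cc2)cc1`) and compound 2 (`COc1ccc(/C=C/c2cc(OC)c(OC)c(OC)c2-c2ccc3ccccc3c2)cc1`) share one core and differ in a single group. In a functional assay on HeLa cells (Homo sapiens) for cytotoxicity, read by MTT assay, with a stated time of 48 h (a higher number here means a weaker inhibitor, a lower number a stronger inhibitor), compound 1 gives 19000 nM, and compound 2 gives 13000 nM. Compound 2 therefore has the lowest number of the two on paper, but its nearest and only neighbour is compound 1, and the two values lie within the scatter of each other, so no ranking follows.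

Compound 3 (`COc1ccc(/C=C/c2cc(OC)c(OC)c(OC)c2-c2ccc(Cl)cc2)cc1`) is the next case: 4-chlorophenyl in place of naphthalen-2-yl on an aromatic carbon. The change is 4-chlorophenyl in place of naphthalen-2-yl, on the aromatic carbon that is ortho to a 2-(4-methoxyphenyl)ethenyl group. Among the compounds with values here, one measured step bears on it, at that same carbon: a 1.5-fold lower number from compound 1 to compound 2 (0.16 log units; within the scatter). Within the data shown here, that step is small, and no measured compound yet carries 4-chlorophenyl, so the evidence is thin. No step beyond the scatter is expected in this assay, and the estimated step is a 1.2-fold higher number from compound 2 to compound 3 (0.06 log units; within the scatter). For compound 3 the expected value is 15000 nM, with an estimated range of 7000 nM to 32000 nM.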

Compound 3, half-maximal inhibitory concentration: 49000 nM
The estimate for compound 3 lay 3.3-fold (0.51 log units) below the measured number; measured number outside the range, above it.
By their numbers in this assay, from the lowest: compounds 2 and 1 (each within the scatter of the next); then compound 3.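

In this assay this position, the aromatic carbon ortho to a 2-(4-methoxyphenyl)ethenyl group, proves sensitive to the group it carries: 4-chlorophenyl in place of naphthalen-2-yl gives the first step there beyond the scatter (a 3.8-fold higher number from compound 2 to compound 3 (0.58 log units; beyond the scatter)), and chloro in place of methoxy on an aromatic carbon runs the same way (a 2.6-fold higher number from compound 1 to compound 3 (0.41 log units; beyond the scatter)). Compound 1 and compound 2 alone could not show this, since they stand within the scatter of each other and left the position looking indifferent to the exchange. Compound 3 now has the highest number of the three, with both of its steps beyond the scatter, though both are modest and rest on a single chlorinated compound, so they mark one substituent and not a trend.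

Nothing on hand accounts for the higher number of compound 3.

The compounds shown leave open whether an amine or a carboxylic acid in place of the chloro would bring the number back towards compound 1 and compound 2 or raise it further. Also open, going by these compounds, is whether a fluoro or a hydroxy group there would track compound 3.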